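Fluorobenzyl change carried onto an isopropyl-bearing core

The source may hold more compounds than are shown below. What is called first, only, known or untested is meant among the compounds shown, and "the series" means these compounds.

Measured compounds in a functional assay for inhibition, with Rattus norvegicus as the target; on this read-out higher numbers stand for weaker inhibition and lower numbers for stronger inhibition:
compound 1, `O=C(CCc1cn(Cc2ccccc2)c2ccc(Cl)cc12)Nc1ccncc1`, gives 740 nM
compound 2, `O=C(CCc1cn(Cc2ccc(F)cc2)c2ccc(Cl)cc12)Nc1ccncc1`, gives 1300 nM
compound 3, `CC(C)c1ccc2c(c1)c(CCC(=O)Nc1ccncc1)cn2Cc1ccccc1`, gives 6000 nM

Compound 4, `CC(C)c1ccc2c(c1)c(CCC(=O)Nc1ccncc1)cn2Cc1ccc(F)cc1`, has not been measured. It differs from compound 3 by fluoro in place of hydrogen on an aromatic carbon, and the same change separates compound 1 from compound 2, namely (fluoro in place of hydrogen on an aromatic carbon); the two place lines read alike, so this is the same change. That earlier step gave a 1.8-fold higher number from compound 1 to compound 2 (0.24 log units; within the scatter). The two cores differ by isopropyl in place of chloro on an aromatic carbon, a step that gave an 8.1-fold higher number from compound 1 to compound 3 (0.91 log units; beyond the scatter). Resting on the step from compound 1 to compound 2, the step from compound 3 to compound 4 is expected to be a 1.5-fold higher number from compound 3 to compound 4 (0.18 log units; within the scatter). Compound 4 is therefore estimated at 9000 nM, expected to lie between 4000 nM and 20000 nM.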

Compound 4, half-maximal inhibitory concentration: 5340 nM
The estimate for compound 4 lay 1.7-fold (0.23 log units) above the measured number, within the range that was stated.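

In this assay, the fluoro change on the core of compound 3 gave a 1.1-fold lower number from compound 3 to compound 4 (0.05 log units; within the scatter), and it matched the same change on the core of compound 1: the same change on two cores in this assay, a 1.8-fold higher number (0.24 log units; within the scatter) from compound 1 to compound 2 and a 1.1-fold lower number (0.05 log units; within the scatter) from compound 3 to compound 4, 2.0-fold (0.30 log units) apart, within the scatter of two such steps. The isopropyl change, now read with the 4-fluorobenzyl group in place, gave a 4.1-fold higher number from compound 2 to compound 4 (0.61 log units; beyond the scatter), and it agreed with the step read with the benzyl group: the same change on two cores in this assay, an 8.1-fold higher number (0.91 log units; beyond the scatter) from compound 1 to compound 3 and a 4.1-fold higher number (0.61 log units; beyond the scatter) from compound 2 to compound 4, 2.0-fold (0.30 log units) apart, within the scatter of two such steps. Both changes thus carried across these four compounds, but the fluoro steps lie within the scatter, so they do not show that this change has any effect of its own, and one pair of cores says nothing about other cores in the series.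

The compounds shown leave open how a methoxy or trifluoromethyl group in place of fluoro would behave. They also leave open whether a longer chain in place of the propanamide chain would carry these steps unchanged.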